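Replacing a chlorofluorophenyl group with a nitrothiophene

The compounds below may be only part of what the source reports. "The series", "measured", "known", "first", "only" and "open" are said of these compounds alone.

Compound 1 `Cc1oc2c([C@H]3CCN(C)C[C@H]3O)c(O)cc(O)c2c(=O)c1C(O)c1ccc([N+](=O)[O-])cc1`: 0%
Compound 2 `Cc1oc2c([C@H]3CCN(C)C[C@H]3O)c(O)cc(O)c2c(=O)c1C(O)c1c(F)cccc1Cl`: 49%
Compound 3 `Cc1oc2c([C@H]3CCN(C)C[C@H]3O)c(O)cc(O)c2c(=O)c1C(O)c1csc([N+](=O)[O-])c1`: not yet measured

In a functional assay on HL-60 cells (Homo sapiens) for inhibition, read by MTT assay, with a stated time of 48 h, tested at 10 uM (a higher number here means more inhibition of growth at the concentration tested, a lower number less inhibition of growth), compound 2 is the higher of the two measured compounds, at 49%. Going on to compound 3 changes one group: 5-nitrothiophen-3-yl in place of 2-chloro-6-fluorophenyl on a saturated chain carbon bound to an aromatic carbon and an oxygen on a saturated carbon. Among the compounds with values here, only one measured step bears on this change: a number 49 percentage points higher from compound 1 to compound 2 (beyond the scatter). That step is large and lies beyond the scatter, and it came with 2-chloro-6-fluorophenyl replacing 4-nitrophenyl. Compound 3 now removes that same group and brings in another nitro-bearing ring, so compound 1, at 0%, is the closest guide. A thiophene is not a phenyl ring, however, and one step is thin evidence. A fall beyond the scatter is therefore expected in this assay, undoing much of the earlier rise, with an expected change of a number 34 percentage points lower from compound 2 to compound 3 (beyond the scatter). The estimated value for compound 3 is 15%, with an expected range of 0% to 40%.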

Compound 3, percent growth inhibition at one concentration: 45%
Estimate against measurement, compound 3: 30 percentage points below, outside the stated range (above it).
By their numbers in this assay, from the lowest: compound 1; then compounds 3 and 2 (each within the scatter of the next).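

In this assay, putting 5-nitrothiophen-3-yl where 2-chloro-6-fluorophenyl stood gives a number 4 percentage points lower from compound 2 to compound 3 (within the scatter) so these two quite different rings cannot be told apart at this position. A nitro group on the ring therefore does not by itself mean a loss of growth inhibition: replacing 4-nitrophenyl with 5-nitrothiophen-3-yl gives a number 45 percentage points higher from compound 1 to compound 3 (beyond the scatter) and compound 1 alone stays low among these three. Nothing measured here explains the gap between the two nitro-bearing rings.

From the compounds shown here alone, it remains open whether the nitro group matters at all on the thiophene, since a plain thiophen-3-yl ring would separate the ring from its substituent. An amine in place of the nitro group on either ring would likewise test how much that substituent contributes.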